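Removing the Bromo Group from Compound 2

The source may hold more compounds than are shown below. What is called first, only, known or untested is meant among the compounds shown, and "the series" means these compounds.

- compound 1 `COc1ccc(C(=O)/C=C\Nc2ccc(-c3nc4cc(OC)c(OC)c(OC)c4s3)cc2C)cc1F` gives 2900 nM
- compound 2 `COc1cc(C(=O)/C=C\Nc2ccc(-c3nc4cc(OC)c(OC)c(OC)c4s3)cc2C)c(Br)c(OC)c1OC` gives 7300 nM

Both compounds were tested in a functional assay on MDA-MB-231 cells (Homo sapiens) for antiproliferative activity, read by sulforhodamine B assay, with a stated time of 48 h; a higher number here means a weaker inhibitor, a lower number a stronger inhibitor. Only these two values are available, and they differ in more than one place, so no single-change step can be read from them. Compound 2, at 7300 nM, has the higher number of the pair, and its gap to compound 1 lies beyond the usual scatter. On this evidence, compound 2 is the weaker inhibitor of the two.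

The next compound, compound 3 `COc1cc(C(=O)/C=C\Nc2ccc(-c3nc4cc(OC)c(OC)c(OC)c4s3)cc2C)cc(OC)c1OC`, has not yet been measured in this assay. It departs from compound 2 by one change, (hydrogen in place of bromo on an aromatic carbon), with hydrogen in place of bromo on an aromatic carbon. Within the data shown here, compound 1 also carries no bromo and gives 2900 nM, which is the only guide to the direction. A moderate fall in the number is therefore expected, though one measured comparison cannot settle it, and a step within the scatter remains possible. The expected change is a 2.4-fold lower number from compound 2 to compound 3 (0.39 log units; beyond the scatter). For compound 3 the estimated value is 3000 nM, with an expected range from 700 nM to 9000 nM.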

Compound 3, half-maximal inhibitory concentration: 12900 nM
Estimate against measurement, compound 3: 4.3-fold (0.63 log units) below; the whole stated range lies below it.
By their numbers in this assay, from the lowest: compound 1; then compounds 2 and 3 (each within the scatter of the next).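

In this assay, replacing bromo with hydrogen on this aromatic carbon, ortho to a large group and ortho to a methoxy group, gives a 1.8-fold higher number from compound 2 to compound 3 (0.25 log units; within the scatter), so this change does not separate the two compounds in this assay. The aryl group on the carbonyl carbon is a different matter: 3,4,5-trimethoxyphenyl in place of 3-fluoro-4-methoxyphenyl gives a 4.4-fold higher number from compound 1 to compound 3 (0.65 log units; beyond the scatter), a modest step but the only one shown here that lies beyond the scatter, which places the visible difference in the overall aryl group rather than in the bromo. Nothing measured here accounts for either step.

Going by these compounds, whether chloro, a hydroxyl group or an amine on the same aromatic carbon would also leave the number within the scatter of compound 3 remains open. Also open is which part of the aryl change carries the larger step, since no compound shown separates the fluoro of compound 1 from the additional methoxy group of compound 3.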